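A few compounds are considered here, and "the series" means these few. Any claim that something is new, unique, unknown or untested is made for them only; others in the source may bear on it.

Measured so far:
compound 1 `COc1ccc(-c2nc(C)c(C(=O)CSc3nc(-c4ccc(Cl)c(Cl)c4)c(C#N)c(=O)[nH]3)s2)cc1` — 88.6%
compound 2 `COc1ccc(-c2nc(C)c(C(=O)CSc3nc(-c4ccc(OC)c(OC)c4)c(C#N)c(=O)[nH]3)s2)cc1` — 57.6%
compound 3 `COc1ccc(-c2nc(C)c(C(=O)CSc3nc(-c4ccc(Cl)cc4)c(C#N)c(=O)[nH]3)s2)cc1` — 92.7%

In a functional assay on U-87MG ATCC cells for antiproliferative activity against U-87 MG (Homo sapiens), read by MTT assay, with a stated time of 48 h, tested at 10 uM (on this read-out higher numbers stand for a weaker effect at the one concentration tested and lower numbers for a stronger effect), compound 3 gives 92.7%, the highest of the three numbers shown; its gap to compound 1 lies within the scatter (a number 4.1 percentage points higher from compound 1 to compound 3 (within the scatter)), and only compound 2 stands apart (a number 35.1 percentage points higher from compound 2 to compound 3 (beyond the scatter)). Compound 4 `COc1ccc(-c2nc(C)c(C(=O)CSc3nc(-c4cccc(Cl)c4)c(C#N)c(=O)[nH]3)s2)cc1` differs from compound 3 by 3-chlorophenyl in place of 4-chlorophenyl on an aromatic carbon. Among the compounds with values here, the one measured step that touches this ring without exchanging it for a different group, hydrogen in place of chloro from compound 1 to compound 3, stayed within the scatter (a number 4.1 percentage points higher from compound 1 to compound 3 (within the scatter)). Within the data shown here, no measured step shifts a chloro around the ring, so the change has no direct precedent. The expectation is therefore no step beyond the scatter, a number 2.7 percentage points lower from compound 3 to compound 4 (within the scatter). Compound 4 is estimated at 90%, with a range from 78% to 99%.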

Compound 4, a percentage reported as activity, at one concentration (the size of the read-out at that concentration, not a potency): 90.6%
The estimate for compound 4 lay 0.6 percentage points below the measured number; low and high end bracket the measured number.
By their numbers in this assay, from the lowest: compound 2; then compounds 1, 4 and 3 (each within the scatter of the next).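

In this assay, shifting the chloro from 4-chlorophenyl to 3-chlorophenyl gives no step beyond the scatter (a number 2.1 percentage points lower from compound 3 to compound 4 (within the scatter)), so this shift of the chloro has no readable effect here. Removing the second chloro of the 3,4-dichlorophenyl group also stays within the scatter (a number 2 percentage points higher from compound 1 to compound 4 (within the scatter)), while replacing 3,4-dimethoxyphenyl with 3-chlorophenyl is a large step (a number 33 percentage points higher from compound 2 to compound 4 (beyond the scatter)), leaving the 3,4-dimethoxyphenyl group alone among these four. Nothing measured here explains these steps.

Open, going by these compounds, is whether a single methoxy group or an amine such as dimethylamino on this phenyl ring would match the number of compound 2. A single concentration also leaves potency unresolved.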